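Sulfonyl aryl substituent: trifluoromethyl to trifluoromethoxy

This account rests on a few compounds, and the source may have more. Where it says the series, first, only, none or still open, it means among the compounds named here.

Among the measured compounds shown here, compound 2 `CN(C)c1ccc(C2CC(c3ccc(-n4cncn4)cc3)=NN2S(=O)(=O)c2ccc(C(F)(F)F)cc2)cc1` holds the highest of the two numbers so far in a functional assay on NCI-H1975 cells (Homo sapiens) for inhibition, read by sulforhodamine B assay, tested at 10 uM (on this read-out lower numbers stand for less inhibition and higher numbers for more inhibition at the one concentration tested (going by the name of the read-out)), where compound 2 gives 5.5%. Its nearest neighbour is compound 1 `CN(C)c1ccc(C2CC(c3ccc(-n4cncn4)cc3)=NN2S(=O)(=O)c2ccc(Br)cc2)cc1`, which in this assay gives -0.6%; the step of a number 6.1 percentage points higher from compound 1 to compound 2 (within the scatter) lies within the scatter, so the two numbers count as level, and both numbers sit close to zero.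

Compound 3 `CN(C)c1ccc(C2CC(c3ccc(-n4cncn4)cc3)=NN2S(=O)(=O)c2ccc(OC(F)(F)F)cc2)cc1` is the next member. Its change from compound 2: trifluoromethoxy in place of trifluoromethyl on an aromatic carbon. For the measured compounds named here, the only measured step at this aromatic carbon is a number 6.1 percentage points higher from compound 1 to compound 2 (within the scatter), and it remained within the scatter; nothing has been measured for trifluoromethoxy itself. The expectation for this assay is therefore no step beyond the scatter and no clear direction, because the step of a number 6.1 percentage points higher from compound 1 to compound 2 (within the scatter) at the same carbon showed none. The estimated step of a number 1.5 percentage points lower from compound 2 to compound 3 (within the scatter) is small. Compound 3 is accordingly estimated at 4%, with a range from -10% to 18%.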

Compound 3, a percentage reported as inhibition, at one concentration (the size of the read-out at that concentration, not a potency): 11.1%
Compound 3: middle estimate off by 7.1 percentage points, on the low side; low and high end bracket the measured number.
By their numbers in this assay, from the lowest: compounds 1, 2 and 3 (each within the scatter of the next, the first and the last beyond it).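

In this assay, trifluoromethoxy in place of trifluoromethyl on this aromatic carbon, para to a large group, gives a number 5.6 percentage points higher from compound 2 to compound 3 (within the scatter), so these two groups count as level. Among the compounds shown here, what is new at this position is that trifluoromethoxy in place of bromo gives a number 11.7 percentage points higher from compound 1 to compound 3 (beyond the scatter), the first step here to leave the scatter, although it is modest and the intermediate compound 2 is within the scatter of both ends. Even so, compound 3 gives only 11.1%, so this change shows a small separation at the single concentration tested rather than strong inhibition. No available measurement bears on why the numbers fall this way.

Still open, going by these compounds, is whether a group of a different kind on this aromatic carbon, such as an amine, a carboxylic acid or a nitrile, would give a step larger than the modest one seen here. The rest of the shared core is the same in compounds 1, 2 and 3, so these compounds say nothing about what a change elsewhere in the core would do in this assay.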